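Moving the Fluorine on the Phenyl Ring

This account rests on a few compounds, and the source may have more. Where it says the series, first, only, none or still open, it means among the compounds named here.

In a functional assay on NCI/ADR-RES cells (Homo sapiens) for inhibition, read by sulforhodamine B assay, with a stated time of 48 h, tested at 10 uM (on this read-out higher numbers stand for more inhibition at the one concentration tested (going by the name of the read-out) and lower numbers for less inhibition), compound 2 `Fc1ccc(-c2cn3ccnc3c(-c3ccc4ncn(C5CCCCC5)c4c3)n2)cc1` gives 0.69%. This is the lowest of the three numbers recorded, but it sits within the usual scatter of both neighbours: compound 1 `c1ccc2c(-c3cn4ccnc4c(-c4ccc5ncn(C6CCCCC6)c5c4)n3)cccc2c1` gives 4.43%, and compound 3 `CC(=O)c1ccc(-c2cn3ccnc3c(-c3ccc4ncn(C5CCCCC5)c4c3)n2)cc1` gives 4.17%. The steps that led to compound 2 are correspondingly small: a number 3.7 percentage points lower from compound 1 to compound 2 (within the scatter), and onward a number 3.5 percentage points higher from compound 2 to compound 3 (within the scatter). The step now followed leads to compound 4 `Fc1ccccc1-c1cn2ccnc2c(-c2ccc3ncn(C4CCCCC4)c3c2)n1`, where the change is 2-fluorophenyl in place of 4-fluorophenyl on an aromatic carbon. Among the compounds with values here, no measured step exchanges one fluorophenyl for another, so the closest guides are the exchanges of the whole aromatic group just named, all of which stayed within the scatter, as did the exchange of acetyl for fluoro. On that basis no step beyond the scatter is expected in this assay, in either direction, and the estimated step is a number 1.8 percentage points higher from compound 2 to compound 4 (within the scatter). Compound 4 is therefore expected to give about 2.5% in this assay, with a likely range from -6% to 11%.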

Compound 4, a percentage reported as inhibition, at one concentration (the size of the read-out at that concentration, not a potency): 4.51%
For compound 4 the middle estimate is 2 percentage points below the measured one, within the range that was stated.
By their numbers in this assay, from the lowest: compounds 2, 3, 1 and 4 (each within the scatter of the next).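

In this assay, within the data shown here, the first exchange of one fluorophenyl for another at this position, 2-fluorophenyl in place of 4-fluorophenyl, comes to a number 3.8 percentage points higher from compound 2 to compound 4 (within the scatter) and shows that, in this pair, where the fluorine sits on the phenyl ring does not take the number beyond the scatter. The other two new exchanges read the same way, with 2-fluorophenyl in place of 4-acetylphenyl giving a number 0.3 percentage points higher from compound 3 to compound 4 (within the scatter) and 2-fluorophenyl in place of naphthalen-1-yl giving a number 0.1 percentage points higher from compound 1 to compound 4 (within the scatter) so that all four groups at this position remain within the scatter of one another. No evidence is available that bears on this result.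

All four groups are carbon aromatic rings, so the compounds leave open whether an amine or a carboxylic acid on the phenyl ring would give a number beyond the scatter. They also leave open whether replacing the cyclohexyl group would do so.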